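A few compounds are considered here, and "the series" means these few. Any claim that something is new, unique, unknown or untested is made for them only; others in the source may bear on it.

Of the compounds shown here, three have been tested in an ADME assay on the whole organism for inhibition, with Triticum aestivum as the target, with a stated time of 5 days (a higher number here means a weaker inhibitor, a lower number a stronger inhibitor), and a fourth awaits measurement. Compound 1, `CCCC1Oc2ccc(F)cc2N(O)C1=O`, carries a propyl group on a saturated ring carbon; in this assay compound 1 gives 766000 nM. Compound 2, `O=C1C(c2ccccc2)Oc2ccc(F)cc2N1O`, has a phenyl group at that same saturated ring carbon, and in this assay compound 2 gives 641000 nM. Setting these two side by side shows that the change propyl in place of phenyl on a saturated ring carbon made only a 1.2-fold higher number from compound 2 to compound 1 (0.08 log units; within the scatter), a step within the usual scatter of repeated measurements, so the two values cannot be told apart.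

Compound 3, `O=C1C(c2ccccc2)Oc2c(Cl)cccc2N1O`, also bears the phenyl group but sits on a different core; the difference between the cores of compound 3 and compound 2 is not broken down here. In this assay compound 3 gives 263000 nM, the lowest of the three numbers, and its distance from each of the other two lies beyond the scatter.

Compound 4, `CCCC1Oc2c(Cl)cccc2N(O)C1=O`, has not yet been measured. It is obtained from compound 3 by propyl in place of phenyl on a saturated ring carbon, the same change already seen between the first two compounds, with the surroundings of the place described in the same words. Because that earlier step was a 1.2-fold higher number from compound 2 to compound 1 (0.08 log units; within the scatter), a similarly small step a 1.1-fold higher number from compound 3 to compound 4 (0.06 log units; within the scatter) is expected. Compound 4 is therefore estimated at 300000 nM, with a likely range from 150000 nM to 600000 nM.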

Compound 4, half-maximal inhibitory concentration: 393000 nM
The estimate for compound 4 lay 1.3-fold (0.12 log units) below the measured number, and the stated range covers the measured number.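

In this assay, among the compounds shown here, putting propyl in place of phenyl on the saturated ring carbon gave a 1.5-fold higher number from compound 3 to compound 4 (0.17 log units; within the scatter), so on this second core the change again produces no step that can be told apart from the ordinary spread of repeated measurements. Set side by side, the two steps agree, and the change behaves alike on both cores as far as these numbers can tell: the same change on two cores in this assay, a 1.2-fold higher number (0.08 log units; within the scatter) from compound 2 to compound 1 and a 1.5-fold higher number (0.17 log units; within the scatter) from compound 3 to compound 4, 1.3-fold (0.10 log units) apart, within the scatter of two such steps. This shows that, for these two pairs, a small step seen on one core was a fair guide to the step on the other, but it does not show that the same would hold on further cores in the series, and steps this small could hide a slight real difference between the cores.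

The compounds shown leave open what other groups would do on this saturated ring carbon, for example an amine, a carboxylic acid or a chain longer than propyl. They also leave open whether a change that produces a large step, rather than one within the scatter, would carry from one core to the other as faithfully as this one did.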